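Swapping in 4-hydroxyphenyl at the limit of the assay

The source may hold more compounds than are shown below. What is called first, only, known or untested is meant among the compounds shown, and "the series" means these compounds.

In a functional assay on MDA-MB-231 cells (Homo sapiens) for cytotoxicity, read by MTT assay, with a stated time of 48 h (a higher number here means a weaker inhibitor, a lower number a stronger inhibitor), compound 1 (`COc1ccc(Nc2nc(-c3cccc(F)c3)nc3ccc(F)cc23)cc1`) gives 47300 nM. Compound 2 (`Fc1cccc(-c2nc(Nc3ccccc3F)c3cc(F)ccc3n2)c1`) reports only a limit, > 50000 nM. Compound 3 (`Fc1cccc(-c2nc(Nc3cccc(Cl)c3)c3cc(F)ccc3n2)c1`) also reports only a limit, > 50000 nM. Compound 4 (`Oc1ccc(Nc2nc(-c3cccc(F)c3)nc3ccc(F)cc23)cc1`) has 4-hydroxyphenyl in place of 3-chlorophenyl on a nitrogen on an aromatic ring. Changes at that nitrogen so far give an at least 1.0-fold higher number from compound 1 to compound 2 (0.02 log units; that floor lies within the scatter), an at least 1.0-fold higher number from compound 1 to compound 3 (0.02 log units; that floor lies within the scatter) and a step that the two limits leave unreadable from compound 2 to compound 3. None of these shows a step beyond the scatter, so none is expected in this assay here. For the measured compounds named here, the only numeric anchor is compound 1 at 47300 nM. The expected change is an at least 1.2-fold lower number from compound 3 to compound 4 (0.09 log units; that floor lies within the scatter). Compound 4 is estimated at 40000 nM, with an expected range of 18000 nM to 50000 nM.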

Compound 4, half-maximal inhibitory concentration: > 50000 nM
Compound 4: no number, only a limit (the forecaster's own chance of this, stated with the estimate: 40%); middle value at least 1.2-fold (0.09 log units) from the limit.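

Hydrogen in place of methyl on the oxygen gives an at least 1.0-fold higher number from compound 1 to compound 4 (0.02 log units; that floor lies within the scatter), so in this assay this change shows no step beyond the scatter. With 4-hydroxyphenyl on the nitrogen, the series again gives only a limit, as with 2-fluorophenyl and 3-chlorophenyl. The steps to compound 4 from compound 2 and compound 3 cannot be read because both ends of each are limits: the limit of > 50000 nM in this assay, at which 3 of the 4 values shown sit.

On these data alone, how far these groups differ beyond the limit stays open. As far as these compounds go, whether a 4-aminophenyl or 4-carboxyphenyl group on this nitrogen would give a clear number also stays open.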